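A few compounds are considered here, and "the series" means these few. Any claim that something is new, unique, unknown or untested is made for them only; others in the source may bear on it.

Measured so far in an assay on MDA-MB-231 cells for binding affinity to C-X-C chemokine receptor type 4 (Homo sapiens), read by fluorescence and microscopy, with stated times of 10 min and 30 min; on this read-out higher numbers stand for an effect only at larger amounts of compound and lower numbers for an effect already at smaller amounts:
compound 1, `O=C(NCc1ccc(CNS(=O)(=O)c2cccc(C(F)(F)F)c2)cc1)c1ccc(F)cc1`: 100 nM
compound 2, `O=C(NCc1ccc(CNS(=O)(=O)c2cccnc2)cc1)c1ccc(F)cc1`: 1000 nM

For the measured compounds named here, compound 1 holds the lowest of the two numbers in this assay; its only neighbour is compound 2, reached by a 10-fold higher number from compound 1 to compound 2 (1.00 log units; beyond the scatter), a step that exchanges the whole ring on the sulfonyl sulfur and so also removes the trifluoromethyl group.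

Compound 3, `O=C(NCc1ccc(CNS(=O)(=O)c2cccc(F)c2)cc1)c1ccc(F)cc1`, is not yet measured. It differs from compound 1 in one place: fluoro in place of trifluoromethyl on an aromatic carbon. The ring on the sulfonyl sulfur is kept, so the change is a narrower one than the step to compound 2. Going by the values given here, only that step bears on it at all, and it shows that taking the trifluoromethyl group away along with the ring change was costly in this assay. Replacing the trifluoromethyl by fluoro alone is expected to cost part of that, not all of it, so a rise in number beyond the scatter is expected, of the order of a 2.5-fold higher number from compound 1 to compound 3 (0.40 log units; beyond the scatter). Compound 3 is therefore estimated at 250 nM in this assay, with a range from 100 nM to 700 nM.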

Compound 3, effective concentration (reported as EC, without a stated level of effect): 1000 nM
The estimate for compound 3 lay 4.0-fold (0.60 log units) below the measured number, and the stated range ends below it.
By their numbers in this assay, from the lowest: compound 1; then compounds 2 and 3 (each within the scatter of the next).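

Working from this assay, the exchange of trifluoromethyl for fluoro on the kept ring is a large step on its own (a 10-fold higher number from compound 1 to compound 3 (1.00 log units; beyond the scatter)), and it matches in size the earlier exchange of the whole ring (a 10-fold higher number from compound 1 to compound 2 (1.00 log units; beyond the scatter)). The 3-fluorophenyl and pyridin-3-yl rings are not separated on the sulfonyl sulfur (no change at the digits printed from compound 2 to compound 3 (within the scatter)), so among these three compounds the higher number goes with the loss of trifluoromethyl and needs no change of ring atoms to appear. At this position a single fluoro therefore does not retain the value of compound 1 (100 nM), and nothing available explains why this exchange has so large an effect.

Still open, from the compounds shown here alone, is whether other groups on the same aromatic carbon, such as chloro, methyl, methoxy or a plain hydrogen, stay with compound 1 or with compound 3. Also open, going by these compounds, is whether trifluoromethyl placed on the pyridin-3-yl ring of compound 2 would bring the number back down.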